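Adding one carbon to the chain of compound 2

This account rests on a few compounds, and the source may have more. Where it says the series, first, only, none or still open, it means among the compounds named here.

Compound 1 `CCC/C=C/C(=O)Nc1cccc(Oc2nc(Nc3ccn(C)n3)nc3c2CSCC3)c1` gives 22600 nM
Compound 2 `CC/C=C/C(=O)Nc1cccc(Oc2nc(Nc3cccc(C#N)c3)nc3c2CSCC3)c1` gives 15900 nM

Both values come from a functional assay on MCF7 cells (Homo sapiens) for antiproliferative activity, read by MTT assay, with a stated time of 72 h (a higher number here means a weaker inhibitor, a lower number a stronger inhibitor), and lie within the usual scatter of each other, so compound 2 stands level with compound 1 and neither can be ranked above the other. Compound 3 `CCC/C=C/C(=O)Nc1cccc(Oc2nc(Nc3cccc(C#N)c3)nc3c2CSCC3)c1` is not yet measured. It departs from compound 2 by methyl in place of hydrogen on a saturated chain carbon, two bonds along the chain from a double-bonded chain carbon and so has methyl in place of hydrogen on a saturated chain carbon, turning but-1-en-1-yl into pent-1-en-1-yl. Going by the values given here, no measured pair shows this change alone. In this assay no step beyond the scatter is expected, because compound 1 with its pent-1-en-1-yl chain gives 22600 nM despite also differing elsewhere. The expected change is a 1.1-fold lower number from compound 2 to compound 3 (0.03 log units; within the scatter) and remains within the scatter. For compound 3 the estimated value is 15000 nM with an expected range from 7500 nM to 30000 nM.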

Compound 3, half-maximal inhibitory concentration: 15300 nM
The estimate for compound 3 lay 1.0-fold (0.01 log units) below the measured number, within the range that was stated.
By their numbers in this assay, from the lowest: compounds 3, 2 and 1 (each within the scatter of the next).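

In this assay, the saturated chain carbon two bonds along the chain from a double-bonded chain carbon now has a reading of its own: methyl in place of hydrogen there, turning but-1-en-1-yl into pent-1-en-1-yl, gives a 1.0-fold lower number from compound 2 to compound 3 (0.02 log units; within the scatter) and leaves the two compounds level. The same holds at the other place, where 3-cyanophenyl in place of 1-methyl-1H-pyrazol-3-yl on a nitrogen on an aromatic ring gives a 1.5-fold lower number from compound 1 to compound 3 (0.17 log units; within the scatter) and does not separate the pair. Nothing measured here accounts for either result.

The compounds shown leave open whether a longer chain, a branched chain or a chain ending in an amine would move the number beyond the scatter. They also leave open whether a group other than these two on the nitrogen, such as a carboxylic acid on the phenyl ring, would do so.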